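Moving a ring nitrogen on the sulfonamide arm

This account rests on a few compounds, and the source may have more. Where it says the series, first, only, none or still open, it means among the compounds named here.

Measured so far:
compound 1 `O=C1[C@@H](NS(=O)(=O)c2ccc(-c3ccon3)s2)CCN1CCNc1ccncc1`, which in an assay on isolated protein for inhibition of coagulation factor X (Oryctolagus cuniculus), tested at 1 uM (on this read-out higher numbers stand for more inhibition at the one concentration tested (going by the name of the read-out) and lower numbers for less inhibition), gives 22%
compound 2 `O=C1[C@@H](NS(=O)(=O)c2cc3ncccc3s2)CCN1Cc1cc2c[nH]ccc-2n1`, which in this assay gives 61%

Compound 2 stands highest of these two numbers; compound 1 lies well below it, beyond the usual scatter. Compound 3 `O=C1[C@@H](NS(=O)(=O)c2cc3cccnc3s2)CCN1Cc1cc2c[nH]ccc-2n1` differs from compound 2 only in the group on the sulfonyl sulfur: a group of 9 heavy atoms (7 carbon, 1 nitrogen, 1 sulfur; one five-membered aromatic ring with 1 hetero atom, one six-membered aromatic ring with 1 hetero atom) in place of a group of 9 heavy atoms (7 carbon, 1 nitrogen, 1 sulfur; one five-membered aromatic ring with 1 hetero atom, one six-membered aromatic ring with 1 hetero atom), on a sulfonyl sulfur The two groups have the same atoms, joined differently. Within the data shown here, no such step has been measured, so its size is uncertain; a modest drop, near the scatter, is expected as a number 11 percentage points lower from compound 2 to compound 3 (beyond the scatter). Compound 3 is estimated at 50%, with a range from 25% to 75%.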

Compound 3, a percentage reported as inhibition, at one concentration (the size of the read-out at that concentration, not a potency): 18%
The estimate for compound 3 lay 32 percentage points above the measured number; the measured number lies below the stated range.
By their numbers in this assay, from the lowest: compounds 3 and 1 (each within the scatter of the next); then compound 2.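

Compound 2 and compound 3 carry the same atoms on the sulfonyl sulfur, joined differently, and in this assay that change alone gives a number 43 percentage points lower from compound 2 to compound 3 (beyond the scatter) with the rest of the molecule untouched. Moving the ring nitrogen within this group therefore matters a great deal for this pair, even though the counts of hydrogen-bond donors and acceptors stay the same. Nothing measured here explains the drop. Still open, as far as these compounds go, is whether a chlorine atom or an amine on this group would restore inhibition, and whether the same nitrogen move would matter with a different arm on the shared core.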